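A Nitro Group on the Salicylaldehyde Hydrazone Arm of Compound 1

A few compounds are considered here, and "the series" means these few. Any claim that something is new, unique, unknown or untested is made for them only; others in the source may bear on it.

Measured compounds:
compound 1 `Cc1c(C(=O)N/N=C\c2ccccc2O)oc2cccc(O)c12`, which in a functional assay on PC-3 cells (Homo sapiens) for inhibition (on this read-out lower numbers stand for stronger inhibition and higher numbers for weaker inhibition), gives 8350 nM
compound 2 `Cc1c(C(=O)N/N=C\c2cccc(F)c2O)oc2cccc(O)c12`, which in this assay gives 12700 nM

Compound 1 stands at the lowest of the two numbers in this assay, with compound 2 nearest; the step of a 1.5-fold higher number from compound 1 to compound 2 (0.18 log units; within the scatter) lies within the scatter. Compound 3 `Cc1c(C(=O)N/N=C\c2cc([N+](=O)[O-])ccc2O)oc2cccc(O)c12` carries nitro in place of hydrogen on an aromatic carbon, para to a hydroxy group. Among the compounds with values here, the only measured step bearing on this change is the other ring substitution on the same arm, a 1.5-fold higher number from compound 1 to compound 2 (0.18 log units; within the scatter), which did not move the number beyond the scatter. No shift beyond the scatter is therefore expected for compound 3 in this assay. Compound 3 is estimated at 10000 nM, in a range from 4000 nM to 25000 nM. The step this estimate means, a 1.2-fold higher number from compound 1 to compound 3 (0.08 log units; within the scatter), is expected to stay within the scatter.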

Compound 3, half-maximal inhibitory concentration: 17100 nM
Compound 3: middle estimate off by 1.7-fold (0.23 log units), on the low side; low and high end bracket the measured number.
By their numbers in this assay, from the lowest: compounds 1, 2 and 3 (each within the scatter of the next, the first and the last beyond it).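

In this assay, within the data shown here, nitro para to a hydroxy group gives the first step on this arm that lies beyond the scatter, a 2.0-fold higher number from compound 1 to compound 3 (0.31 log units; beyond the scatter), and it points toward weaker inhibition. The fluoro step, a 1.5-fold higher number from compound 1 to compound 2 (0.18 log units; within the scatter), stayed within the scatter, so a change on this ring is not always without effect, though this shift is modest. Nothing available explains the step. The compounds shown leave open whether an amine, a methoxy group or a carboxylic acid at this same place would also raise the number or would lower it.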